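Removing a Protecting Group from a Ring Amine

The source may hold more compounds than are shown below. What is called first, only, known or untested is meant among the compounds shown, and "the series" means these compounds.

Compound 1 `Cc1ccc(NC(=O)c2cccc(C(F)(F)F)c2)cc1N1Cc2cnc(O[C@H]3CCN(C(=O)OC(C)(C)C)C3)nc2N(C)C1=O` is the starting point. Among the compounds with values here, in an ADME assay on BaF3 cells (Mus musculus) for antiproliferative activity, read by CellTiter-Glo and CCK-8 assay, with a stated time of 72 h (a lower number here means a stronger inhibitor of growth, a higher number a weaker inhibitor of growth), compound 1 gives 8380 nM, the only actual number among the three measured compounds. Compound 2 `Cc1ccc(NC(=O)c2cccc(C(F)(F)F)c2)cc1N1Cc2cnc(OC3CCN(C(=O)OC(C)(C)C)CC3)nc2N(C)C1=O` returns only a limit, > 10000 nM. Compound 3 `Cc1ccc(Nc2ncc3c(n2)N(C)C(=O)N(c2cc(NC(=O)c4cccc(-c5ccccc5)c4)ccc2C)C3)cc1N` likewise stops at a limit, > 10000 nM. Compound 4 `Cc1ccc(NC(=O)c2cccc(C(F)(F)F)c2)cc1N1Cc2cnc(O[C@H]3CCNC3)nc2N(C)C1=O` has not been measured; it differs from compound 1 in one place: hydrogen in place of tert-butoxycarbonyl on an amine nitrogen in a ring. Within the data shown here, no measured step of this kind is available, so the direction rests on the change alone; a moderate gain in growth inhibition, beyond the usual scatter, is expected. The step from compound 1 to compound 4 is estimated as a 2.8-fold lower number from compound 1 to compound 4 (0.45 log units; beyond the scatter). Compound 4 is therefore expected to give about 3000 nM, within 800 nM to 10000 nM, with some chance of only a limit given (the limit of > 10000 nM in this assay, at which 2 of the 3 values shown sit).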

Compound 4, concentration for 50% growth inhibition: > 10000 nM
Compound 4 ended at the assay's limit; the forecaster's own chance of this, stated with the estimate: 20%; middle value at least 3.3-fold (0.52 log units) from the limit.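

In this assay, putting hydrogen in place of tert-butoxycarbonyl on this ring nitrogen gives an at least 1.1-fold higher number from compound 1 to compound 4 (0.07 log units; that floor lies within the scatter), so removing the protecting group brings no visible gain in growth inhibition. On these data alone, compound 4 gives > 10000 nM, which is a limit of the assay and not a number, so the true size of the step stays unknown. Most of the compounds shown now end at this same ceiling: the limit of > 10000 nM in this assay, at which 3 of the 4 values shown sit.

The compounds shown leave open how a methyl or acetyl group on this nitrogen would compare with compound 1. As far as these compounds go, the effect of a longer chain ending in a carboxylic acid also remains open.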